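Adding a Second Fluoro Group: An Expected Potency Shift

The source may report more compounds than this note shows. Statements on the series, on what has been measured and on what is new or still open speak of the compounds shown alone.

compound 1 `Fc1ccccc1/C=C/c1ccccc1`: 700 nM
compound 2 `Cc1ccc(/C=C/c2cccc(F)c2)cc1`: 800 nM
compound 3 `Fc1cccc(F)c1/C=C/c1ccccc1`: 6900 nM

Of the compounds shown here, three have been measured in an assay on HepG2 cells for activation of nuclear factor erythroid 2-related factor 2 (Homo sapiens), read by a luciferase reporter, with a stated time of 5 h; on this read-out lower numbers stand for an effect already at smaller amounts and higher numbers for an effect only at larger amounts of compound. Compound 1 gives 700 nM and compound 2 gives 800 nM; these two differ in their cores, a difference that is not broken down here, and their values lie within the usual scatter of each other. Compound 3 carries fluoro in place of hydrogen on an aromatic carbon, and the measured step was a 9.9-fold higher number from compound 1 to compound 3 (0.99 log units; beyond the scatter).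

Compound 4 `Cc1ccc(/C=C/c2ccc(F)c(F)c2)cc1` carries fluoro in place of hydrogen on an aromatic carbon. This is the same kind of change, not the same one: in compound 4 the entering fluoro is ortho to a fluoro group and para to a group of 9 heavy atoms, whereas in compound 3 it is ortho to a group of 8 heavy atoms and meta to a fluoro group. Resting on a 9.9-fold higher number from compound 1 to compound 3 (0.99 log units; beyond the scatter), a weaker step is expected, a 2.5-fold higher number from compound 2 to compound 4 (0.40 log units; beyond the scatter). Compound 4 is thus estimated at 2000 nM in this assay, expected between 700 nM and 6000 nM.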

Compound 4, half-maximal effective concentration: 2600 nM
The estimate for compound 4 lay 1.3-fold (0.11 log units) below the measured number; the range from low to high includes it.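

In this assay, fluoro in place of hydrogen, entering ortho to a fluoro group and para to a group of 9 heavy atoms, gave a 3.3-fold higher number from compound 2 to compound 4 (0.51 log units; beyond the scatter). The direction of the step carried over from one core to the other, but its size did not: the same change on two cores in this assay, a 9.9-fold higher number (0.99 log units; beyond the scatter) from compound 1 to compound 3 and a 3.3-fold higher number (0.51 log units; beyond the scatter) from compound 2 to compound 4, 3.0-fold (0.48 log units) apart, beyond the scatter of two such steps

Going by these compounds alone, with only two pairs, in which the fluoro also enters at different places, this does not show whether the core or the place of entry sets the size of the step. The compounds shown leave open whether the step would keep its direction on further cores. They also leave open how a group other than fluoro, such as a methoxy group, a nitrile or an amine, would behave at these places.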